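Swapping the sulfamoyl for a carbamoyl on the phenyl ring

A few compounds are considered here, and "the series" means these few. Any claim that something is new, unique, unknown or untested is made for them only; others in the source may bear on it.

Among the measured compounds shown here, the two compounds measured so far share a core in which a seven-carbon chain ending in a phenyl ring is linked through a carbonyl to an oxazole-bearing fragment; compound 1 `O=C(CCCCCCc1ccccc1)c1ncc(-c2ccc(O)cc2)o1` carries a hydroxy on the terminal benzene ring, and compound 2 `NS(=O)(=O)c1ccc(-c2cnc(C(=O)CCCCCCc3ccccc3)o2)cc1` carries a sulfamoyl there. In an assay (Rattus norvegicus) for inhibition of Fatty-acid amide hydrolase 1 (Homo sapiens) (a lower number here means a stronger inhibitor, a higher number a weaker inhibitor), compound 1 gives 140 nM and compound 2 gives 10 nM. For the measured compounds named here, the single step between them, a 14-fold lower number from compound 1 to compound 2 (1.15 log units; beyond the scatter), is the only one available, and it places compound 2 at the lower of the two numbers.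

Compound 3 `NC(=O)c1ccc(-c2cnc(C(=O)CCCCCCc3ccccc3)o2)cc1` differs from compound 2 in one place: carbamoyl in place of sulfamoyl on an aromatic carbon. Going by the values given here, no measured step covers a carbamoyl, so the only guide is that the change from hydroxy to sulfamoyl, a 14-fold lower number from compound 1 to compound 2 (1.15 log units; beyond the scatter), lowered the number substantially, and a carbamoyl shares with sulfamoyl one hydrogen-bond donor and at least one acceptor as counted above. The expected result is a modest step upward, a 2.0-fold higher number from compound 2 to compound 3 (0.30 log units; within the scatter), staying well clear of the number for compound 1. Compound 3 is therefore estimated at 20 nM, with a range from 6 nM to 70 nM.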

Compound 3, inhibition constant: 10 nM
Compound 3: the middle estimate sits 2.0-fold (0.30 log units) above what was measured; the range from low to high includes it.
By their numbers in this assay, from the lowest: compounds 2 and 3 (each within the scatter of the next); then compound 1.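

At this place on the six-membered aromatic ring, para to a large group, this assay shows no change at the digits printed from compound 2 to compound 3 (within the scatter), so sulfamoyl and carbamoyl cannot be told apart here and the sulfur atom of sulfamoyl is not required for a number at this level. The comparison with hydroxy now rests on two groups and not one: the data show a 14-fold lower number from compound 1 to compound 3 (1.15 log units; beyond the scatter), a step as large as the one seen earlier for sulfamoyl, so the earlier gain is not unique to sulfamoyl. No supporting measurement is available to explain why these two groups read alike or why both differ from hydroxy.

The compounds shown leave open how far this tolerance extends, since a carboxylic acid, a methyl ester, a nitrile or a simple amine at the same place would test whether other groups also give numbers in this range or fall back toward the number for hydroxy. They also leave open whether adding a methyl to the carbamoyl nitrogen, or using a shorter chain on the other side of the carbonyl, would keep the number where it stands.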